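Swapping phenyl for ethoxycarbonyl on the amide carbonyl

This account rests on a few compounds, and the source may have more. Where it says the series, first, only, none or still open, it means among the compounds named here.

Compound 1 `COc1cc(/C=C/C(=O)c2cccc(NC(=O)c3c(Cl)cccc3Cl)c2)ccc1O` gives 88% in a functional assay on HUVEC cells (Homo sapiens) for inhibition, tested at 5 ug/mL; a lower number here means a weaker effect, a higher number a stronger effect of the compound at the concentration tested.
Compound 2 `COC(=O)C(=O)Nc1cccc(C(=O)/C=C/c2ccc(O)c(OC)c2)c1` gives 20% in this assay.
Compound 3 `COc1cc(/C=C/C(=O)c2cccc(NC(=O)c3ccccc3)c2)ccc1O` gives 48% in this assay.

All three compounds share one core and differ only in the group attached to the carbonyl carbon of the amide. Compound 3 stands second highest of the three numbers in this assay: compound 2 lies well below it, a number 28 percentage points higher from compound 2 to compound 3 (beyond the scatter), while compound 1 lies well above it, a number 40 percentage points lower from compound 1 to compound 3 (beyond the scatter).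

Compound 4 `CCOC(=O)C(=O)Nc1cccc(C(=O)/C=C/c2ccc(O)c(OC)c2)c1` has not yet been tested. It differs from compound 3 in one place: ethoxycarbonyl in place of phenyl on a carbonyl carbon. The most direct guide is the step of a number 28 percentage points higher from compound 2 to compound 3 (beyond the scatter), in which a phenyl replaced a methoxycarbonyl and the number rose; ethoxycarbonyl closely resembles methoxycarbonyl. The change from compound 3 to compound 4 runs the other way, so a drop of roughly that size is expected, a number 26 percentage points lower from compound 3 to compound 4 (beyond the scatter). That would put compound 4 near compound 2. Compound 4 is therefore expected to give about 22% in this assay, somewhere between 5% and 45%.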

Compound 4, a percentage reported as inhibition, at one concentration (the size of the read-out at that concentration, not a potency): 45%
Estimate against measurement, compound 4: 23 percentage points below, within the range that was stated.
By their numbers in this assay, from the lowest: compound 2; then compounds 4 and 3 (each within the scatter of the next); then compound 1.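

In this assay, ethoxycarbonyl does not behave like methoxycarbonyl at this position: a single methyl in place of a hydrogen on the saturated chain carbon bound to the ester oxygen gives a clear step (a number 25 percentage points higher from compound 2 to compound 4 (beyond the scatter)). The new group also shows that the aromatic ring of phenyl is not needed to reach the level of compound 3, since ethoxycarbonyl, which has no ring, stands level with phenyl on this carbonyl carbon (a number 3 percentage points lower from compound 3 to compound 4 (within the scatter)). The 2,6-dichlorophenyl group of compound 1 remains well clear of this ester as well (a number 43 percentage points lower from compound 1 to compound 4 (beyond the scatter)), and no measurement at hand explains any of these differences.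

The compounds shown leave open whether the effect of lengthening the ester continues with a propoxycarbonyl or a longer chain, or whether it stops at ethoxycarbonyl, and what a carboxylic acid or a simple amide would do on this carbonyl carbon. They also leave open whether both chlorines of 2,6-dichlorophenyl are needed, which a phenyl carrying a single chlorine could test.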